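Two Ring Sizes on a Shared Chain, Measured in Breast Cells

This account rests on a few compounds, and the source may have more. Where it says the series, first, only, none or still open, it means among the compounds named here.

Of the compounds shown here, three have been tested in an ADME assay on MCF-10A cells (Homo sapiens) for antiproliferative activity, read by sulforhodamine B assay, with a stated time of 48 h; on this read-out higher numbers stand for weaker inhibition of growth and lower numbers for stronger inhibition of growth. Compound 1 `Clc1ccc2c(NCCCN3CCCC3)ccnc2c1` gives 45800 nM in this assay. Compound 2 `Clc1ccc2c(NCCCN3CCCCC3)ccnc2c1` differs from compound 1 by piperidin-1-yl in place of pyrrolidin-1-yl on a saturated chain carbon, three bonds along the chain from a nitrogen on an aromatic ring, and in this assay compound 2 gives 47800 nM. That change made a step of a 1.0-fold higher number from compound 1 to compound 2 (0.02 log units; within the scatter). Compound 3 `FC(F)(F)c1ccc2c(NCCCN3CCCC3)ccnc2c1` differs from compound 1 by trifluoromethyl in place of chloro on an aromatic carbon, and in this assay compound 3 gives 58700 nM; the step is a 1.3-fold higher number from compound 1 to compound 3 (0.11 log units; within the scatter). All three values lie within the usual scatter of one another.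

Compound 4 `FC(F)(F)c1ccc2c(NCCCN3CCCCC3)ccnc2c1` has not yet been measured. It differs from compound 3 by piperidin-1-yl in place of pyrrolidin-1-yl on a saturated chain carbon, three bonds along the chain from a nitrogen on an aromatic ring, the same change seen from compound 1 to compound 2, at the same place on the chain. Because the earlier step was a 1.0-fold higher number from compound 1 to compound 2 (0.02 log units; within the scatter), the change is expected to leave compound 4 close to compound 3, with an estimated step of a 1.0-fold higher number from compound 3 to compound 4 (0.01 log units; within the scatter). The value expected for compound 4 in this assay is 60000 nM. For compound 4 the estimated range runs from 30000 nM to 120000 nM.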

Compound 4, concentration for 50% growth inhibition: 48800 nM
Compound 4: middle estimate off by 1.2-fold (0.09 log units), on the high side; low and high end bracket the measured number.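

Piperidin-1-yl in place of pyrrolidin-1-yl gives a 1.2-fold lower number from compound 3 to compound 4 (0.08 log units; within the scatter) in this assay and so reads the same as the earlier step on the other core: the same change on two cores in this assay, a 1.0-fold higher number (0.02 log units; within the scatter) from compound 1 to compound 2 and a 1.2-fold lower number (0.08 log units; within the scatter) from compound 3 to compound 4, 1.3-fold (0.10 log units) apart, within the scatter of two such steps. Trifluoromethyl in place of chloro gives a 1.0-fold higher number from compound 2 to compound 4 (0.01 log units; within the scatter) and also reads the same on both cores: the same change on two cores in this assay, a 1.3-fold higher number (0.11 log units; within the scatter) from compound 1 to compound 3 and a 1.0-fold higher number (0.01 log units; within the scatter) from compound 2 to compound 4, 1.3-fold (0.10 log units) apart, within the scatter of two such steps. Among the compounds shown here, every one of these steps lies within the scatter; this shows only that neither change gave a measurable step on either core, and it does not show that a change with a real effect would carry from one core to another in the same way.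

The compounds shown leave open whether a different amine at the end of the chain, such as morpholine, or a longer chain would give a step beyond the scatter. They also leave open how another group in place of chloro, such as a nitrile, would behave on these two cores.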